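A few compounds are considered here, and "the series" means these few. Any claim that something is new, unique, unknown or untested is made for them only; others in the source may bear on it.

Compound 1 `CCCCSc1nnc(COc2ccccc2C2=NOC(c3ccc(Cl)cc3Cl)C2)n1NC(=O)CCl` is one of two compounds in this set with a number in an ADME assay (MDM cells, Homo sapiens) for cytotoxicity, read by resazurin assay, with a stated time of 3 days (on this read-out higher numbers stand for weaker inhibition and lower numbers for stronger inhibition), where compound 1 gives 2.8 ug/mL. Its closest measured neighbour is compound 3 `CCCSc1nnc(COc2ccccc2C2=NOC(c3ccc(Cl)cc3Cl)C2)n1NC(=O)CCl`, which differs only by hydrogen in place of methyl on a saturated chain carbon, three bonds along the chain from a sulfur; compound 3 gives 28.7 ug/mL, so that the change reads a 10-fold higher number from compound 1 to compound 3 (1.01 log units; beyond the scatter). Compound 2 `CCOC(=O)CC(=O)CSc1nnc(COc2ccccc2C2=NOC(c3ccc(Cl)cc3Cl)C2)n1NC(=O)CCl` carries a longer substituent on the same sulfur, but for compound 2 no result was reported in this assay, "not determined" (no result reported).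

Compound 4 `CCCCSc1nnc(COc2ccccc2C2=NOC(c3ccc(Cl)cc3Cl)C2)n1NC(=O)c1ccccc1` keeps the whole of compound 1 apart from one exchange at the amide: phenyl in place of chloromethyl on a carbonyl carbon. Going by the values given here, no measured step in this set touches that amide; the single step from compound 1 to compound 3 concerns the chain on the sulfur and shows only that a small change elsewhere in this core can move the number a long way. Among the compounds with values here, with no precedent at the changed position, the size and direction of the step in this assay cannot be read from the data, and the estimate is therefore wide. Compound 4 is expected to give 8 ug/mL, with a range from 2 ug/mL to 40 ug/mL, which corresponds to an expected step of a 2.9-fold higher number from compound 1 to compound 4 (0.46 log units; beyond the scatter).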

Compound 4, half-maximal inhibitory concentration: 2.5 ug/mL
Compound 4: the middle estimate sits 3.2-fold (0.51 log units) above what was measured; low and high end bracket the measured number.
By their numbers in this assay, from the lowest: compounds 4 and 1 (each within the scatter of the next); then compound 3.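

In this assay, the amide now has its first measured exchange, and phenyl in place of chloromethyl on a carbonyl carbon gives a 1.1-fold lower number from compound 1 to compound 4 (0.05 log units; within the scatter), which lies within the scatter, so the two compounds read alike. In this pair, then, the low number of compound 1 does not rest on the chloromethyl group, since a group with no chlorine and with a six-membered aromatic ring of carbon only gives a number that cannot be told apart from it, whereas the exchange on the chain at the sulfur gives a 10-fold higher number from compound 1 to compound 3 (1.01 log units; beyond the scatter), beyond the scatter. Nothing measured here explains why the amide exchange leaves the two numbers so close.

The compounds shown leave open whether the same holds with the shorter chain on the sulfur of compound 3, where a benzoyl group could show whether the amide and the chain act independently. They also leave open whether a group of another kind on that carbonyl carbon, such as an aminomethyl group, a carboxylic acid or a longer alkyl chain, would read alike or move the number away from that of compound 1.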